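The compounds below may be only part of what the source reports. "The series", "measured", "known", "first", "only" and "open" are said of these compounds alone.

Compound 1 `CCOCC(COCC)Nc1nc(C)nc2c(-c3ccc(OC)cc3C)c(C)nn12` is one of three compounds tested in an assay on cell membranes for displacement of a labelled ligand from corticotropin-releasing factor receptor 1 (Rattus norvegicus) (on this read-out lower numbers stand for stronger inhibition and higher numbers for weaker inhibition), and compound 1 gives 19.3 nM. That is the highest of the three numbers: compound 2 `CCC1CCCCN1c1nc(C)nc2c(-c3c(C)cc(OC)cc3OC)c(C)nn12` gives 3.26 nM and compound 3 `CCCCN(CC)c1nc(C)nc2c(-c3c(C)cc(OC)cc3OC)c(C)nn12` gives 1.72 nM. Both differ from compound 1 in two places, in the amino group on the shared core and in the substituents of the attached aryl ring, so neither pair forms a single-point step. Within the data shown here, the only such step among the measured compounds, a 1.9-fold lower number from compound 2 to compound 3 (0.28 log units; within the scatter), shows that exchanging one amine for another here can stay within the scatter. Compound 4 `CCCN(CC1CC1)c1nc(C)nc2c(-c3ccc(OC)cc3C)c(C)nn12` differs from compound 1 in one place: (cyclopropylmethyl)(propyl)amino in place of (2-ethoxy-1-(ethoxymethyl)ethyl)amino on an aromatic carbon. Among the measured compounds shown here, no measured step covers this change directly. For the measured compounds named here, the amine that enters is closer in kind to the one in compound 3, which gives 1.72 nM, than to the one in compound 1, so a lower number is expected, a 3.9-fold lower number from compound 1 to compound 4 (0.59 log units; beyond the scatter). For compound 4 the estimate is 5 nM, with a range from 1.5 nM to 15 nM.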

Compound 4, half-maximal inhibitory concentration: 1.96 nM
The estimate for compound 4 lay 2.6-fold (0.41 log units) above the measured number, and the stated range covers the measured number.
By their numbers in this assay, from the lowest: compounds 3, 4 and 2 (each within the scatter of the next); then compound 1.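

Among the compounds shown, this is the only single-place change of the amino group that lies beyond the scatter: in this assay, (cyclopropylmethyl)(propyl)amino in place of (2-ethoxy-1-(ethoxymethyl)ethyl)amino gives a 9.8-fold lower number from compound 1 to compound 4 (0.99 log units; beyond the scatter). The group on this aromatic carbon between two ring nitrogen atoms can therefore shift the number clearly, whereas a 1.9-fold lower number from compound 2 to compound 3 (0.28 log units; within the scatter) stays within the scatter. The entering group has no hydrogen-bond donor or oxygen and adds a three-membered ring, all in one step, and nothing measured here explains the difference or separates these features.

Groups such as (cyclopropylmethyl)amino, which keeps the hydrogen on the amine nitrogen, or bis(2-methoxyethyl)amino, which keeps the ether oxygens without it, could help separate them. Also open, on these data alone, is whether the same exchange gives a similar step with the aryl ring of compound 2 and compound 3.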